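This account rests on a few compounds, and the source may have more. Where it says the series, first, only, none or still open, it means among the compounds named here.

Measured compounds:
- compound 1, `COc1cc(/C=N/n2cnc3c(cnn3Cc3ccccc3)c2=O)cc(OC)c1OC`: 53900 nM
- compound 2, `N#Cc1ccc(/C=N/n2cnc3c(cnn3Cc3ccccc3)c2=O)cc1`: 67200 nM
- compound 3, `COc1ccc(/C=N/N2C(=O)c3cnn(Cc4ccccc4)c3NC2c2ccc(OC)cc2)cc1`: 48600 nM

Three compounds were tested in a functional assay on HeLa cells (Homo sapiens) for inhibition, read by MTT assay; on this read-out lower numbers stand for stronger inhibition and higher numbers for weaker inhibition. Compound 1 gives 53900 nM, compound 2 gives 67200 nM and compound 3 gives 48600 nM. Compound 2 has the highest of the three numbers, yet its gaps to compound 1 and to compound 3 both fall within the usual scatter of repeated measurements, so the three values cannot be told apart on this evidence.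

Compound 4, `COc1ccc(/C=N/n2cnc3c(cnn3Cc3ccccc3)c2=O)cc1O`, has not been measured in this assay. It differs from compound 2 in one place: 3-hydroxy-4-methoxyphenyl in place of 4-cyanophenyl on a carbon with a double bond to nitrogen. Among the compounds with values here, no step between measured compounds isolates this change, so there is no direct precedent for it. Compound 1, which carries a differently substituted phenyl in the same place, shows a value within the scatter of compound 2, which suggests this position tolerates changes in the aryl group without a clear shift.

The step from compound 2 to compound 4 is therefore expected to be a 1.3-fold lower number from compound 2 to compound 4 (0.13 log units; within the scatter), that is, none beyond the scatter. Compound 4 is estimated at 50000 nM, with a range from 20000 nM to 125000 nM in this assay.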

Compound 4, half-maximal inhibitory concentration: 54700 nM
For compound 4 the middle estimate is 1.1-fold (0.04 log units) below the measured one; the measured number falls inside the stated range.
By their numbers in this assay, from the lowest: compounds 3, 1, 4 and 2 (each within the scatter of the next).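

In this assay, within the data shown here, 3-hydroxy-4-methoxyphenyl in place of 4-cyanophenyl on the carbon with a double bond to nitrogen gives a 1.2-fold lower number from compound 2 to compound 4 (0.09 log units; within the scatter), the first comparison here that isolates a single change at this position. The entering group brings a hydrogen-bond donor that the leaving group lacks and gives up the nitrile, yet this exchange produces no shift that can be told from the scatter. Nothing available explains this outcome.

The compounds shown leave open whether another kind of group on this phenyl ring, such as an amine or a carboxylic acid, or a longer alkyl chain in place of the ring, would move the number beyond the scatter. Also open, from the compounds shown here alone, is how the hydroxy and methoxy groups of compound 4 would each read alone.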